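The source may report more compounds than this note shows. Statements on the series, on what has been measured and on what is new or still open speak of the compounds shown alone.

Compound 1 `COc1cc(C(=O)NNC(=S)Nc2csc(-c3ccc(C)cc3)c2)cc(OC)c1OC`: 31000 nM
Compound 2 `COc1ccc(C(=O)NNC(=S)Nc2csc(-c3ccccc3)c2)cc1OC`: 21000 nM

In a functional assay on MCF7 cells (Homo sapiens) for inhibition, read by colorimetric assay and MTT assay, with a stated time of 72 h (a lower number here means a stronger inhibitor, a higher number a weaker inhibitor), compound 2 gives the lower of the two numbers, but its gap to compound 1 lies within the usual scatter, so the two cannot be told apart on these data. Compound 3 `COc1ccc(C(=O)NNC(=S)Nc2csc(-c3ccc(C)cc3)c2)cc1OC` differs from compound 2 in one place: methyl in place of hydrogen on an aromatic carbon. Among the measured compounds shown here, no step between two measured compounds that differ in only one place is available, so the size of this change cannot be read off from anything already measured. Compound 1 carries the same methyl, yet it also differs from compound 2 elsewhere, so its value says nothing clean about the methyl alone. The step of no change at the digits printed from compound 2 to compound 3 (within the scatter) is expected to stay within the scatter, with no firm direction. Compound 3 is therefore expected to give about 21000 nM in this assay, most likely between 8000 nM and 50000 nM.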

Compound 3, half-maximal inhibitory concentration: 11000 nM
Compound 3: the middle estimate sits 1.9-fold (0.28 log units) above what was measured; low and high end bracket the measured number.
By their numbers in this assay, from the lowest: compounds 3, 2 and 1 (each within the scatter of the next, the first and the last beyond it).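

In this assay, the change from phenyl to 4-methylphenyl gives a 1.9-fold lower number from compound 2 to compound 3 (0.28 log units; within the scatter) and so stays within the scatter: on these data, the methyl at this position, para to a large group, brings no change that can be told from noise. The step that does clear the scatter lies at another place, where an aromatic carbon carrying methoxy in compound 1 carries hydrogen in compound 3; this gives a 2.8-fold lower number from compound 1 to compound 3 (0.45 log units; beyond the scatter) and is a modest step. Nothing measured here explains either step.

On these data alone, it remains open whether a group other than methyl at the same position, such as an amine or a longer chain like propyl, would move the number beyond the scatter. As far as these compounds go, whether the methoxy step would hold on the unsubstituted phenyl also remains open.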